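From compound 1 to compound 3: a chloro for a hydrogen

The compounds below may be only part of what the source reports. "The series", "measured", "known", "first", "only" and "open" are said of these compounds alone.

Compound 1, `OCc1cn(Cc2ccccc2)c2ccccc12`, was tested in a functional assay on T29Kt1 cells (Homo sapiens) for cytotoxicity, read by sulforhodamine B assay, with a stated time of 3 days (a lower number here means a stronger inhibitor, a higher number a weaker inhibitor), where compound 1 gives 30 nM. That is the highest of the two numbers recorded so far; the other belongs to compound 2, `OCc1cn(Cc2cccc(F)c2)c2ccccc12`, which in this assay gives 20 nM. Within the data shown here, the only measured step between these two, a 1.5-fold lower number from compound 1 to compound 2 (0.18 log units; within the scatter), does not reach beyond the scatter.

Compound 3, `OCc1cn(Cc2ccccc2Cl)c2ccccc12`, has not yet been measured. It differs from compound 1 in a single place: chloro in place of hydrogen on an aromatic carbon. Among the measured compounds shown here, the one measured step that bears on this change is a 1.5-fold lower number from compound 1 to compound 2 (0.18 log units; within the scatter), in which a halogen also entered the same ring, though fluoro rather than chloro; that step stayed within the scatter. On this basis a halogen entering this ring is expected to move the number little, so the step of no change at the digits printed from compound 1 to compound 3 (within the scatter) is estimated to remain within the usual scatter. The estimate for compound 3 in this assay is therefore 30 nM, with a range from 12 nM to 75 nM.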

Compound 3, half-maximal inhibitory concentration: 2510 nM
For compound 3 the middle estimate is 84-fold (1.92 log units) below the measured one; the measured number lies above the stated range.
By their numbers in this assay, from the lowest: compounds 2 and 1 (each within the scatter of the next); then compound 3.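

In this assay, among these compounds, a single chloro on an aromatic carbon, ortho to a large group, gives an 84-fold higher number from compound 1 to compound 3 (1.92 log units; beyond the scatter), a much weaker inhibitor, whereas the only earlier halogen step, a 1.5-fold lower number from compound 1 to compound 2 (0.18 log units; within the scatter), stayed within the scatter. The ring of compound 1 is therefore not indifferent to a halogen: one heavy atom in place of a hydrogen is enough to produce a large step, although compound 2 shows that a halogen on this ring does not always do so. No measurement shown here accounts for the size of this step.

Compounds 2 and 3 differ from compound 1 in both the halogen and its place on the ring, so the compounds shown cannot tell whether the large step belongs to chloro itself or to the carbon that carries it. On these data alone, it also remains open whether a fluoro, a methyl or a methoxy group on that same carbon would give a step like that of chloro, and whether chloro on the carbon that bears fluoro in compound 2 would stay within the scatter of compound 1.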